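A few compounds are considered here, and "the series" means these few. Any claim that something is new, unique, unknown or untested is made for them only; others in the source may bear on it.

Measured compounds:
compound 1 `Cc1ccc2c(=O)c(CSC(=S)N3CCCCC3)coc2c1` — > 25000 nM
compound 2 `O=c1c(CSC(=S)N2CCOCC2)coc2cc(Cl)ccc12` — 2000 nM

In a functional assay on HeLa cells (Homo sapiens) for antiproliferative activity, read by MTT assay, with a stated time of 72 h (a higher number here means a weaker inhibitor, a lower number a stronger inhibitor), compound 1 gives > 25000 nM, which is a limit of the assay and not a number; it matches (the limit of > 25000 nM in this assay, at which 1 of the 2 values shown sits). For the measured compounds named here, compound 2 is the only compound with a number in this assay, giving 2000 nM. The limit for compound 1 allows no ranking of compound 1 against compound 2 beyond noting that compound 2 does return a number.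

Compound 3 `O=c1c(CSC(=S)N2CCCCC2)coc2cc(Cl)ccc12` is not yet measured in this assay. It differs from compound 2 by piperidin-1-yl in place of morpholin-4-yl on a thiocarbonyl carbon. Going by the values given here, no step between measured compounds that differ in one place is available, so the size of this change has no precedent. Among the compounds with values here, compound 1 also carries piperidin-1-yl but is not a single-change partner of compound 3, and its value is a limit, so it sets no step. The expectation is a step of a 1.5-fold higher number from compound 2 to compound 3 (0.18 log units; within the scatter), within the usual scatter or a modest loss. Compound 3 is thus estimated at 3000 nM, between 1000 nM and 12000 nM.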

Compound 3, half-maximal inhibitory concentration: 440 nM
Compound 3: middle estimate off by 6.8-fold (0.83 log units), on the high side; the whole stated range lies above it.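

In this assay, for the compounds shown here, the first step with numbers at both ends on this thiocarbonyl carbon is a 4.5-fold lower number from compound 2 to compound 3 (0.66 log units; beyond the scatter), so piperidin-1-yl in place of morpholin-4-yl is a real gain on the chloro core and not a neutral exchange. With piperidin-1-yl held constant, the second step, an at least 56-fold lower number from compound 1 to compound 3 (1.75 log units; beyond the scatter), comes from chloro in place of methyl on an aromatic carbon, which shows that the aromatic substituent also shapes the read-out in this series. The value of compound 1 is a limit of the assay and not a number: the limit of > 25000 nM in this assay, at which 1 of the 3 values shown sits.

The compounds shown leave open how a smaller ring such as pyrrolidin-1-yl, or an open-chain amine such as diethylamino, would compare with piperidin-1-yl on the thiocarbonyl carbon. Also open, going by these compounds, are whether fluoro or methoxy could stand in for chloro on the aromatic carbon, and whether the step from morpholin-4-yl to piperidin-1-yl keeps its size when methyl replaces chloro.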